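The source may hold more compounds than are shown below. What is called first, only, known or untested is meant among the compounds shown, and "the series" means these compounds.

For the measured compounds named here, compound 1 `COc1ccc(-c2cc(=O)c3c(OC)cc(OC)cc3n2S(=O)(=O)c2cccc(Br)c2)cc1` is one of three compounds measured in a functional assay on SUP-B15 cells (Homo sapiens) for antiproliferative activity, with a stated time of 72 h; a lower number here means that less compound is needed, a higher number that more compound is needed for the effect. In this assay compound 1 gives > 58600 nM, which is a limit and not a number. Compound 2 `COc1ccc(-c2cc(=O)c3c(OC)cc(OC)cc3n2S(=O)(=O)c2ccc(Br)cc2)cc1` carries a 4-bromophenyl in place of a 3-bromophenyl on the sulfonyl sulfur, and in this assay compound 2 gives 63800 nM. The step that the limit leaves unreadable from compound 1 to compound 2 cannot be read because compound 1 sits at the limit (the limit of > 58600 nM in this assay, at which 1 of the 3 values shown sits).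

Compound 3 `COc1cc(OC)c2c(=O)cc(C(=O)Nc3ccc(C4CCCCC4)cc3)[nH]c2c1` stands at a limit of its own. In this assay compound 3 gives > 43100 nM, a limit and not a number (the limit of > 43100 nM in this assay, at which 1 of the 3 values shown sits). Compound 4 `COc1cc(OC)c2c(=O)cc(C(=O)Nc3ccc(Oc4ccc(F)cc4)cc3)[nH]c2c1` differs from compound 3 by 4-fluorophenoxy in place of cyclohexyl on an aromatic carbon. Going by the values given here, the only step between measured compounds, a step that the limit leaves unreadable from compound 1 to compound 2, is unreadable in size, and no measured step touches the group that changes here. So nothing among the measured compounds points to a shift in either direction beyond the scatter, and the starting point is a limit. The expected step is a step that the limit leaves unreadable from compound 3 to compound 4, in no readable direction. Compound 4 is therefore estimated at 50000 nM, within 15000 nM to 150000 nM, with a real chance that only a limit is reported.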

Compound 4, half-maximal effective concentration: > 50000 nM
Compound 4 ended at the assay's limit (the forecaster's own chance of this, stated with the estimate: 60%); the middle value sits exactly at the limit.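

Compound 3 and compound 4 both stand at limits in this assay, and the step between them cannot be read, either in size or in direction. The compounds shown leave open how far each of the two lies from its limit, and whether 4-fluorophenoxy in place of cyclohexyl changes the read-out at all.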